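This account rests on a few compounds, and the source may have more. Where it says the series, first, only, none or still open, it means among the compounds named here.

Working notes on the series.

Compound 2 `Cc1nc(Nc2ccccc2)sc1C(=O)/C=C/c1ccccc1` gives 19500 nM in a functional assay on BGC-823 cells (Homo sapiens) for cytotoxicity, read by MTT assay; on this read-out higher numbers stand for weaker inhibition and lower numbers for stronger inhibition. Compound 1 `Cc1cccc(Nc2nc(C)c(C(=O)/C=C/c3ccccc3)s2)c1` differs from compound 2 by methyl in place of hydrogen on an aromatic carbon, which gave a 1.4-fold lower number from compound 2 to compound 1 (0.16 log units; within the scatter). Compound 3 `Cc1nc(Nc2ccccc2)sc1C(=O)/C=C/c1ccccc1Cl` gives 22800 nM in this assay; the cores of compound 2 and compound 3 differ by chloro in place of hydrogen on an aromatic carbon. Compound 4 `Cc1ccc(Nc2nc(C)c(C(=O)/C=C/c3ccccc3Cl)s2)cc1` differs from compound 3 by methyl in place of hydrogen on an aromatic carbon. This is the same kind of change as that from compound 2 to compound 1, not the same: there the entering methyl sits meta to a large group, here para to a large group, and the cores differ as noted. For the measured compounds named here, with only one earlier instance, which stayed within the scatter, a step of similar size is expected. Compound 4 is estimated at 18000 nM, between 9000 nM and 36000 nM. The expected step is a 1.3-fold lower number from compound 3 to compound 4 (0.10 log units; within the scatter), resting on compound 1 at 13600 nM against compound 2.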

Compound 4, half-maximal inhibitory concentration: > 25000 nM
Compound 4 gave a limit, no number; the forecaster's own chance of this, stated with the estimate: 10%; middle value at least 1.3-fold (0.14 log units) away from the limit.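

In this assay compound 4 gives > 25000 nM, which is a limit of the assay and not a number. The step, an at least 1.0-fold higher number from compound 3 to compound 4 (0.04 log units; that floor lies within the scatter), is only a floor: it does not show that methyl in place of hydrogen carries over from the core of compound 2 to the core of compound 3, nor that it fails to carry over. Set side by side, the two instances of the change read: the same change on two cores in this assay, a 1.4-fold lower number (0.16 log units; within the scatter) from compound 2 to compound 1 and an at least 1.0-fold higher number (0.04 log units; that floor lies within the scatter) from compound 3 to compound 4; the limit leaves it open whether they differ

The compounds shown leave open how the change behaves on any further core. They also leave open what an amine or a carboxylic acid would give in place of the methyl.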